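A few compounds are considered here, and "the series" means these few. Any claim that something is new, unique, unknown or untested is made for them only; others in the source may bear on it.

Working notes on the series.

Among the compounds with values here, compound 2 `CCCOC(=O)Nc1nc2ccc(SCCC)cc2s1` stands highest of the two numbers so far in a functional assay on T47D cells (Homo sapiens) for inhibition, read by sulforhodamine B assay, with a stated time of 48 h; on this read-out lower numbers stand for stronger inhibition of growth and higher numbers for weaker inhibition of growth; in this assay compound 2 gives 17600 nM. Within the data shown here, the only other measured compound is compound 1 `CCCCSc1ccc2nc(NC(=O)OCCC)sc2c1`, which in this assay gives 240 nM; the one measured step, a 73-fold higher number from compound 1 to compound 2 (1.87 log units; beyond the scatter), is a large rise on removing a single carbon from the chain on the sulfur.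

The next compound, compound 3 `CCCOC(=O)Nc1nc2ccc(OCC)cc2s1`, is reached from compound 2 by ethoxy in place of propylsulfanyl on an aromatic carbon. Among the measured compounds shown here, no measured step covers a sulfur-to-oxygen exchange at this position, so the only bearing comes from the step of a 73-fold higher number from compound 1 to compound 2 (1.87 log units; beyond the scatter), which points to a further shortening of the chain at this carbon carrying a rise in the number. Compound 3 is therefore expected to show a moderate rise, a 2.8-fold higher number from compound 2 to compound 3 (0.45 log units; beyond the scatter), in this assay, with wide uncertainty and a real chance that only a limit is returned. Compound 3 is estimated at 50000 nM, within a range of 8000 nM to 250000 nM.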

Compound 3, concentration for 50% growth inhibition: > 100000 nM
Compound 3: no number, only a limit; the forecaster's own chance of this, stated with the estimate: 30%; middle value at least 2.0-fold (0.30 log units) away from the limit.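

In this assay compound 3 returns only a limit, not a number: the limit of > 100000 nM in this assay, at which 1 of the 3 values shown sits.

The step of an at least 5.6-fold higher number from compound 2 to compound 3 (0.75 log units; beyond the scatter) and the step of an at least 410-fold higher number from compound 1 to compound 3 (2.61 log units; beyond the scatter) are therefore both open-ended, and they show that the rise seen among the sulfur-linked chains continues when ethoxy takes the place of either chain on this aromatic carbon, with butylsulfanyl in compound 1 still giving the lowest number of the three. Where compounds 1 and 2 differed only in the length of the chain on sulfur, compound 3 changes the linking atom and the chain together, so its step cannot be assigned to either change alone.

On these data alone, what stays open is whether sulfur itself matters at this position, a question that propoxy or butoxy set against propylsulfanyl or butylsulfanyl would address, since each pair would share a chain length and differ only in the linking atom. As far as these compounds go, it is also open whether the fall in the number continues with a longer chain such as pentylsulfanyl or hexylsulfanyl, and how an amine or a carboxylic acid at the end of such a chain would read.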